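Extending the chain from compound 3 to compound 4

The source may report more compounds than this note shows. Statements on the series, on what has been measured and on what is new or still open speak of the compounds shown alone.

Values in a functional assay for inhibition, read by fluorescence and spectrophotometry, with a stated time of 30 h (a higher number here means a weaker inhibitor, a lower number a stronger inhibitor), for the measured compounds
- compound 1 `COc1ccc(-c2cc(=O)c3ccc(OCCCCN4CCC(C)CC4)cc3o2)cc1` gives 48200 nM
- compound 2 `COc1ccc(-c2cc(=O)c3ccc(OCCCCN4CCC(CCO)CC4)cc3o2)cc1` gives 38400 nM
- compound 3 `COc1ccc(-c2cc(=O)c3ccc(OCCCCCN4CCC(CCO)CC4)cc3o2)cc1` gives 49400 nM

Compound 3 stands level with compound 1 and compound 2, as all three numbers lie within the scatter of one another. The next structure is compound 4 `COc1ccc(-c2cc(=O)c3ccc(OCCCCCCCN4CCC(C)CC4)cc3o2)cc1` and the change is 2-(4-methylpiperidin-1-yl)ethyl in place of 4-(2-hydroxyethyl)piperidin-1-yl on a saturated chain carbon, five bonds along the chain from an oxygen on an aromatic ring in words 2-(4-methylpiperidin-1-yl)ethyl in place of 4-(2-hydroxyethyl)piperidin-1-yl on a saturated chain carbon, five bonds along the chain from an oxygen on an aromatic ring.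

Within the data shown here, three measured steps bear on this. Changing only the ring substituent gave a 1.3-fold lower number from compound 1 to compound 2 (0.10 log units; within the scatter) and lengthening only the chain gave a 1.3-fold higher number from compound 2 to compound 3 (0.11 log units; within the scatter) while both changes together gave a 1.0-fold higher number from compound 1 to compound 3 (0.01 log units; within the scatter) and none of these leaves the scatter. Among the measured compounds shown here, no measured compound carries a chain as long as that of compound 4, so the range is kept wide. With a 1.0-fold higher number from compound 1 to compound 3 (0.01 log units; within the scatter) as the closest guide, no step beyond the scatter is expected in this assay for this change. The expected step is a 1.2-fold lower number from compound 3 to compound 4 (0.09 log units; within the scatter) as an estimate with no firm direction. The estimated value for compound 4 is 40000 nM with an expected range from 15000 nM to 80000 nM for this measurement.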

Compound 4, half-maximal inhibitory concentration: 61600 nM
Beside the measured number, compound 4's estimate is 1.5-fold (0.19 log units) below it; the range from low to high includes it.
By their numbers in this assay, from the lowest: compounds 2, 1, 3 and 4 (each within the scatter of the next).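

In this assay, the series now reaches a longer chain without leaving the scatter: replacing 4-methylpiperidin-1-yl with 3-(4-methylpiperidin-1-yl)propyl gives a 1.3-fold higher number from compound 1 to compound 4 (0.11 log units; within the scatter). Replacing 4-(2-hydroxyethyl)piperidin-1-yl with 3-(4-methylpiperidin-1-yl)propyl gives a 1.6-fold higher number from compound 2 to compound 4 (0.21 log units; within the scatter), and replacing it with 2-(4-methylpiperidin-1-yl)ethyl gives a 1.2-fold higher number from compound 3 to compound 4 (0.10 log units; within the scatter), so these changes, which also take the count from 1 hydrogen-bond donor to 0, do not separate compound 4 from the other three compounds. No supporting data bear on this flat result.

Compound 4 differs from compound 2 and compound 3 in both chain length and ring substituent, so a compound pairing its chain with 4-(2-hydroxyethyl)piperidin-1-yl would be needed to read either change alone. From the compounds shown here alone, it also remains open whether a shorter chain, a morpholine in place of the piperidine, or a carboxylic acid on the piperidine ring would give a step beyond the scatter in this assay.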